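Nitro in place of methoxy: a cytotoxicity ceiling expected

The source may report more compounds than this note shows. Statements on the series, on what has been measured and on what is new or still open speak of the compounds shown alone.

Compound 1 `COc1ccccc1-c1cnc(NC(=O)c2ccc(F)cc2)n1C` in a toxicity assay on THP-1 cells (Homo sapiens) for inhibition (on this read-out higher numbers stand for lower toxicity in this test and lower numbers for higher toxicity in this test), gives only the assay's limit, > 100000 nM.
Compound 2 `Cn1c(-c2cccc(C#N)c2)cnc1NC(=O)c1ccc(F)cc1` in this assay gives only the assay's limit, > 100000 nM.
Compound 3 `COc1cccc(-c2cnc(NC(=O)c3ccc(F)cc3)n2C)c1` in this assay gives only the assay's limit, > 100000 nM.

Compound 1 therefore stands nowhere that a number can pin down: its value is a limit, and the same holds for the two other compounds measured in this assay, as the limit of > 100000 nM in this assay, at which 3 of the 3 values shown sit, records. The steps between them say nothing about size: a step that the two limits leave unreadable from compound 1 to compound 2, a step that the two limits leave unreadable from compound 1 to compound 3 and a step that the two limits leave unreadable from compound 2 to compound 3 are all unreadable because both ends sit at the limit.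

Compound 4 `Cn1c(-c2ccccc2[N+](=O)[O-])cnc1NC(=O)c1ccc(F)cc1` differs from compound 1 in one place: nitro in place of methoxy on an aromatic carbon. Going by the values given here, no measured step bears on this exchange, and none of the three measured steps yields a readable size, so there is no basis for expecting a move in either direction beyond the scatter of this assay. The plain expectation is that compound 4 behaves like the three compounds measured, with the step of a number no higher from compound 1 to compound 4 (the limit leaves the size open) expected to be flat. Compound 4 is accordingly estimated at 100000 nM, within 30000 nM to 300000 nM, and it is expected most likely to return a limit again rather than a number.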

Compound 4, half-maximal cytotoxic concentration: 31000 nM
For compound 4 the middle estimate is 3.2-fold (0.51 log units) above the measured one, and the stated range covers the measured number.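

On the aromatic carbon ortho to a large group, nitro in place of methoxy gives an at least 3.2-fold lower number from compound 1 to compound 4 (0.50 log units; beyond the scatter), so a change at this place can bring a real number in this assay. The earlier steps cannot be read, and compound 4 is the only compound shown that leaves the limit: the limit of > 100000 nM in this assay, at which 3 of the 4 values shown sit. On these data alone, the true size of the new step stays open, since compound 1 has only a limit, and the step therefore gives a minimum rather than a measured distance.

The compounds shown do not tell whether the change comes from the arrival of the nitro group or from the loss of the methoxy, and they do not show whether nitro on another carbon of the same ring would do the same. Nor do they tell whether an amine or a carboxylic acid on this same aromatic carbon would stay at the limit in this assay or give a number.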